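Branching the Amide Nitrogen Substituent in the Series

A few compounds are considered here, and "the series" means these few. Any claim that something is new, unique, unknown or untested is made for them only; others in the source may bear on it.

The series shares one core bearing an amine-carrying acyl chain. Going by the values given here, compound 1 `CC[C@@H](NC(=O)CC(C)(C)N)C(=O)N(Cc1ccc(-c2ccccc2-c2nn[nH]n2)cc1)c1ccccc1` is the only member that returns a number: in a functional assay (Pituitary gland cell) with Rattus norvegicus as the target (a lower number here means that less compound is needed, a higher number that more compound is needed for the effect), compound 1 gives 11 uM. Compound 2 `CN(Cc1ccc(-c2ccccc2-c2nn[nH]n2)cc1)C(=O)[C@@H](CCc1ccccc1)NC(=O)CCC(C)(C)N` returns only a limit of the assay in this assay, compound 2 giving > 0.3 uM. Compound 3 `CCN(Cc1ccc(-c2ccccc2-c2nn[nH]n2)cc1)C(=O)[C@@H](CCc1ccccc1)NC(=O)C(C)(C)N` likewise returns only a limit in this assay, compound 3 giving > 0.5 uM. That limit is the limit of > 0.5 uM in this assay, at which 1 of the 3 values shown sits, so compound 3 has no number of its own to stand on, and nothing in the series places it relative to compound 1. Compound 4 `CC(C)N(Cc1ccc(-c2ccccc2-c2nn[nH]n2)cc1)C(=O)[C@@H](CCc1ccccc1)NC(=O)C(C)(C)N` differs from compound 3 by methyl in place of hydrogen on a saturated chain carbon bound to an amide-type nitrogen and a saturated chain carbon, read one bond further out as ethyl to isopropyl on the amide nitrogen. Among the compounds with values here, no measured step connects any two compounds, so no size can be read off from the series itself. The change is a single added carbon, and a step within the usual scatter in this assay is expected, with no direction favoured. Compound 4 is expected to sit near 3 uM, within 0.7 uM to 15 uM. That corresponds to an estimated step that the limit leaves unreadable from compound 3 to compound 4, with a real chance the assay again returns only a limit.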

Compound 4, concentration for half-maximal effect: > 0.5 uM
Compound 4: only a limit was reported; the forecaster's own chance of this, stated with the estimate: 50%; the middle value is on the limit's open side.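

Compound 3 and compound 4 both return only limits in this assay, so the step between them, ethyl to isopropyl, cannot be read. The compounds shown leave open what number either compound would take and whether this change shifts the read-out at all.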